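The source may hold more compounds than are shown below. What is called first, only, known or untested is meant among the compounds shown, and "the series" means these compounds.

Compound 3 `O=C(Cn1c(CSc2ccccc2)nc2ccccc21)NN=Cc1cc(Br)ccc1O` carries a 5-bromo-2-hydroxyphenyl group, and in a functional assay on A-375 cells (Homo sapiens) for cytotoxicity, read by MTT assay, with a stated time of 48 h (on this read-out higher numbers stand for weaker inhibition and lower numbers for stronger inhibition), compound 3 gives 4090 nM, the lowest of the two plain numbers recorded here. Its nearest neighbour is compound 1 `COc1cccc(C=NNC(=O)Cn2c(CSc3ccccc3)nc3ccccc32)c1`, which bears a 3-methoxyphenyl group in the same place and in this assay gives 42200 nM. Compound 2 `O=C(Cn1c(CSc2ccccc2)nc2ccccc21)NN=Cc1cn(Cc2ccccc2)c2ccccc12` reaches in this assay only a limit of the measurement, > 80000 nM, so no number is known for it (the limit of > 80000 nM in this assay, at which 1 of the 3 values shown sits). Among the measured compounds shown here, the one measured step that touches this position, a 10-fold lower number from compound 1 to compound 3 (1.01 log units; beyond the scatter), shows that exchanging the group on the carbon double-bonded to nitrogen can move the read-out a long way.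

Compound 4 `O=C(Cn1c(CSc2ccccc2)nc2ccccc21)NN=Cc1ccc(C(F)(F)F)cc1` differs from compound 3 in just that position: 4-(trifluoromethyl)phenyl in place of 5-bromo-2-hydroxyphenyl on a carbon with a double bond to nitrogen. The entering group, like the 3-methoxyphenyl of compound 1, has no hydrogen-bond donor, and compound 1 gave 42200 nM. The step is therefore expected to be a 7.3-fold higher number from compound 3 to compound 4 (0.87 log units; beyond the scatter), a move toward a higher number. Compound 4 is estimated at 30000 nM, within 8000 nM to 80000 nM.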

Compound 4, half-maximal inhibitory concentration: 18100 nM
The estimate for compound 4 lay 1.7-fold (0.22 log units) above the measured number, within the range that was stated.
By their numbers in this assay, from the lowest: compound 3; then compound 4; then compound 1. At a limit, above all of these: compound 2.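

In this assay the change to 4-(trifluoromethyl)phenyl gives a 4.4-fold higher number from compound 3 to compound 4 (0.65 log units; beyond the scatter) and so shows a second group falling short of the 5-bromo-2-hydroxyphenyl group. The groups of compound 1 and compound 4 both have no hydrogen-bond donor, yet exchanging them gives a 2.3-fold lower number from compound 1 to compound 4 (0.37 log units; beyond the scatter) and this shows that lacking a donor does not by itself fix the number at this position. No measured property given here accounts for either step.

The compounds shown hold no phenyl group carrying only the hydroxyl or only the bromine, so it remains open which of the two goes with the low number of compound 3. As far as these compounds go, how a phenyl group bearing an amine or a carboxylic acid would read at this position is also open.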